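The source may hold more compounds than are shown below. What is called first, only, known or untested is meant among the compounds shown, and "the series" means these compounds.

Compound 1 `COc1ccccc1-n1nncc1CN1C(=O)C2(C(C#N)=C(N)Oc3c(N)cc4nc5ccccc5nc4c32)c2ccccc21`: in a functional assay on HCT-116 cells (Homo sapiens) for antiproliferative activity, read by MTT assay, with a stated time of 48 h (on this read-out lower numbers stand for stronger inhibition and higher numbers for weaker inhibition), compound 1 gives only a limit, > 50000 nM.
Compound 2 `Cc1ccc(Cl)cc1-n1nncc1CN1C(=O)C2(C(C#N)=C(N)Oc3c(N)cc4nc5ccccc5nc4c32)c2ccccc21`: in this assay compound 2 gives 37200 nM.

For the measured compounds named here, compound 2 is the only compound of the pair with a number; the other value shown is a limit. Going by the values given here, the one measured comparison, an at least 1.3-fold lower number from compound 1 to compound 2 (0.12 log units; that floor lies within the scatter), has its floor set by the limit of > 50000 nM in this assay, at which 1 of the 2 values shown sits, so it fixes no size beyond the scatter and gives no direction that could be trusted.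

Compound 3 `Cc1cc(C)c(-n2nncc2CN2C(=O)C3(C(C#N)=C(N)Oc4c(N)cc5nc6ccccc6nc5c43)c3ccccc32)c(C)c1` differs from compound 2 on an aromatic nitrogen: 2,4,6-trimethylphenyl in place of 5-chloro-2-methylphenyl on an aromatic nitrogen. Among the compounds with values here, the only measured step that bears on this position is an at least 1.3-fold lower number from compound 1 to compound 2 (0.12 log units; that floor lies within the scatter), and it stays within the scatter. Nothing in the two measured compounds points to a larger move, so for this assay no step beyond the scatter, in either direction, is expected for compound 3. Compound 3 is therefore expected to give 40000 nM in this assay, with a range from 15000 nM to 110000 nM. This expectation amounts to the step of a 1.1-fold higher number from compound 2 to compound 3 (0.03 log units; within the scatter). Since compound 1 sits at a limit, compound 3 is also expected to carry a fair chance of returning a limit rather than a number.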

Compound 3, half-maximal inhibitory concentration: > 50000 nM
Compound 3: only a limit was reported; the forecaster's own chance of this, stated with the estimate: 40%; at least 1.2-fold (0.09 log units) between middle value and limit.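

In this assay, placing 2,4,6-trimethylphenyl where compound 2 carries 5-chloro-2-methylphenyl gives an at least 1.3-fold higher number from compound 2 to compound 3 (0.12 log units; that floor lies within the scatter), so this second change on the aromatic nitrogen, like the first, fixes no size beyond the scatter. For the compounds shown here, compound 3 gives only a limit, and it is the second of the three compounds to do so, which leaves compound 2 as the only one with a number and makes the step between compound 1 and compound 3 unreadable. The three groups on this nitrogen therefore cannot be ranked, and the result adds a second substituted phenyl that yields no number, with the readings crowded at one end of the range: the limit of > 50000 nM in this assay, at which 2 of the 3 values shown sit.

The compounds shown leave open whether any group at this position can move the number beyond the scatter, for example an amine or a carboxylic acid on the phenyl ring, or a longer alkyl chain in place of that ring. They also leave open whether the position matters at all in this assay, since every change shown stays on this one phenyl ring and the shared core never varies.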